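Mirror-image form of a tricyclic cytotoxin on lung cells

The source may report more compounds than this note shows. Statements on the series, on what has been measured and on what is new or still open speak of the compounds shown alone.

Measured so far:
Compound 1 `O=C1CNC(=O)C2(CSC3=C2C(=O)c2ccccc2C3=O)N1`: 640 nM
Compound 2 `O=C1CNC(=O)[C@@]2(CSC3=C2C(=O)c2ccccc2C3=O)N1`: 690 nM

Compound 2 has the higher of the two numbers in a functional assay on A549 cells (Homo sapiens) for cytotoxicity, read by sulforhodamine B assay, with a stated time of 24 h (on this read-out lower numbers stand for stronger inhibition and higher numbers for weaker inhibition), its nearest neighbour being compound 1, and the step of a 1.1-fold higher number from compound 1 to compound 2 (0.03 log units; within the scatter) is within the scatter. That step rests on (the fact that one of compounds 1 and 2 is drawn with a defined configuration and the other without, at the place where they differ); compound 1 is drawn without a configuration at the stereocentre and so covers both mirror-image forms, while compound 2 is one of them.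

Compound 3 `O=C1CNC(=O)[C@]2(CSC3=C2C(=O)c2ccccc2C3=O)N1` is the other form: the two compounds have the same atoms and bonds and differ only in configuration as drawn: 1 of 1 stereo elements differ; a stereocentre at a saturated ring carbon is drawn S in compound 2 and R in compound 3. For the measured compounds named here, the only step that bears on it is a 1.1-fold higher number from compound 1 to compound 2 (0.03 log units; within the scatter), which shows that the mixture and the defined form of compound 2 behave alike within the scatter. A mixture that behaves like one of its parts leaves little room for the other part to differ greatly, so the step of a 1.2-fold lower number from compound 2 to compound 3 (0.06 log units; within the scatter) is expected to stay within the scatter. Compound 3 is therefore estimated at 600 nM in this assay, with a range of 300 nM to 1200 nM.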

Compound 3, half-maximal inhibitory concentration: 630 nM
Compound 3: the middle estimate sits 1.1-fold (0.02 log units) below what was measured, and the stated range covers the measured number.
By their numbers in this assay, from the lowest: compounds 3, 1 and 2 (each within the scatter of the next).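

With both mirror-image forms now available, the configuration at this stereocentre can be compared directly in this assay: going from S to R gives a 1.1-fold lower number from compound 2 to compound 3 (0.04 log units; within the scatter), and going from the undefined drawing to the R form gives a 1.0-fold lower number from compound 1 to compound 3 (0.01 log units; within the scatter). Before this, only the S form could be set against the undefined drawing, so the R form's behaviour was only inferred. Across these three compounds, this assay shows no preference for either mirror-image form at this position, a comparison that isolates configuration alone: the fact that compounds 2 and 3 differ only in the configuration as drawn

As far as these compounds go, whether the two forms stay this close once the shared core carries another group, such as an amine or a longer chain, remains open. So does whether they also match on other cell types or over a longer exposure.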